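Replacing piperazin-1-yl with (6-aminohexyl)amino

This account rests on a few compounds, and the source may have more. Where it says the series, first, only, none or still open, it means among the compounds named here.

Measured so far in a functional assay on HCT-116 cells (Homo sapiens) for cytotoxicity, read by MTT assay, with a stated time of 72 h (a lower number here means a stronger inhibitor, a higher number a weaker inhibitor), for three compounds
- compound 1 `Nc1cccc(Nc2c(C(=O)NCc3ccc(F)cc3)nc(Br)c3cccnc23)c1` gives > 10000 nM as a limit
- compound 2 `N[C@H]1CC[C@H](Nc2c(C(=O)NCc3ccc(F)cc3)nc(Br)c3cccnc23)CC1` gives 7000 nM as a number
- compound 3 `O=C(NCc1ccc(F)cc1)c1nc(Br)c2cccnc2c1N1CCNCC1` gives > 10000 nM as a limit

Compound 3 stands at the limit of > 10000 nM in this assay, at which 2 of the 3 values shown sit, and so has a limit rather than a number. Compound 4 `NCCCCCCNc1c(C(=O)NCc2ccc(F)cc2)nc(Br)c2cccnc12` keeps the same core. The change (6-aminohexyl)amino in place of piperazin-1-yl on an aromatic carbon puts (6-aminohexyl)amino in place of piperazin-1-yl on an aromatic carbon.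

The nearest measured case is the reverse kind of swap, with piperazin-1-yl in place of (4-aminocyclohexyl)amino, seen as an at least 1.4-fold higher number from compound 2 to compound 3 (0.15 log units; that floor lies within the scatter) in size. The step that the two limits leave unreadable from compound 1 to compound 3 adds little here. Like compound 4, compound 2 ends its group in a free amine and gives 7000 nM as its value. A modest move to a lower number is therefore expected, though one within the scatter would be no surprise. The expected step is an at least 1.6-fold lower number from compound 3 to compound 4 (0.22 log units; that floor lies within the scatter) in size. Compound 4 is estimated at 6000 nM with an expected range of 2000 nM to 15000 nM overall.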

Compound 4, half-maximal inhibitory concentration: 7000 nM
Beside the measured number, compound 4's estimate is 1.2-fold (0.07 log units) below it; low and high end bracket the measured number.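

In this assay, putting 6-aminohexyl in place of 4-aminocyclohexyl on the nitrogen gives no change at the digits printed from compound 2 to compound 4 (within the scatter), so at this position a group with no ring prints the same value as one with a ring. Putting (6-aminohexyl)amino in place of piperazin-1-yl gives an at least 1.4-fold lower number from compound 3 to compound 4 (0.15 log units; that floor lies within the scatter), and putting 6-aminohexyl in place of 3-aminophenyl gives an at least 1.4-fold lower number from compound 1 to compound 4 (0.15 log units; that floor lies within the scatter), so neither step shows a clear gain. These two steps are only floors because compound 1 and compound 3 carry limits rather than numbers: the limit of > 10000 nM in this assay, at which 2 of the 4 values shown sit.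

As far as these compounds go, whether a shorter chain such as 3-aminopropyl would keep this value stays open. So does the part played by the amine at the chain end, which a 6-hydroxyhexyl group in its place would test.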